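Ethynyl for furan-3-yl on the amino-bearing core

This account rests on a few compounds, and the source may have more. Where it says the series, first, only, none or still open, it means among the compounds named here.

Working notes on a small nucleoside series read in an ADME assay on BJ cells (Homo sapiens), read by MTT assay, with a stated time of 72 h; on this read-out lower numbers stand for stronger inhibition and higher numbers for weaker inhibition. Compound 1 `C#Cc1cn([C@@H]2O[C@H](CO)[C@@H](O)[C@H]2O)c2ncnc(OC)c12` carries an ethynyl group and lacks the amino group of the other members; in this assay compound 1 gives 98400 nM. Compound 2 `COc1nc(N)nc2c1c(-c1ccccc1)cn2[C@@H]1O[C@H](CO)[C@@H](O)[C@H]1O` carries a phenyl group. In this assay compound 2 gives only a limit, > 100000 nM. Compound 3 `COc1nc(N)nc2c1c(-c1ccoc1)cn2[C@@H]1O[C@H](CO)[C@@H](O)[C@H]1O` carries a furan-3-yl group. In this assay compound 3 likewise gives only a limit, > 100000 nM. Going by the values given here, two of the three values therefore sit at the limit of > 100000 nM in this assay, at which 2 of the 3 values shown sit, and the one measured step, a step that the two limits leave unreadable from compound 2 to compound 3, is unreadable for that reason.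

Compound 4 `C#Cc1cn([C@@H]2O[C@H](CO)[C@@H](O)[C@H]2O)c2nc(N)nc(OC)c12` is the next member, not yet measured in this assay. The change from compound 3 is ethynyl in place of furan-3-yl on an aromatic carbon. Among the compounds with values here, no measured step bears on this exchange; the only guide is that compound 1, the other ethynyl member, gives 98400 nM, a weak inhibition. The expectation for compound 4 is therefore a value in the same region, with a step of a number no higher from compound 3 to compound 4 (the limit leaves the size open) that cannot be called beyond the scatter. The estimate for compound 4 is 100000 nM, expected between 50000 nM and 200000 nM.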

Compound 4, half-maximal inhibitory concentration: > 100000 nM
Compound 4: a limit, no number (the forecaster's own chance of this, stated with the estimate: 55%); the middle value sits exactly at the limit.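

On the amino-bearing core, ethynyl, which has no ring, still leaves compound 4 at a limit in this assay, as phenyl leaves compound 2 and furan-3-yl leaves compound 3, so removing the ring from this aromatic carbon brings no measured number. The exchanges linking compound 4 to compound 2 and compound 3 cannot be read because both ends of each are limits: the limit of > 100000 nM in this assay, at which 3 of the 4 values shown sit.

Going by these compounds alone, the only readable step is the amino exchange on the ethynyl member, an at least 1.0-fold higher number from compound 1 to compound 4 (0.00 log units; that floor lies within the scatter), so no effect of amino in place of hydrogen can be claimed.

On these data alone, it remains open whether a methyl group, a chlorine atom or a longer alkyne chain on this aromatic carbon would give a number rather than a limit. As far as these compounds go, it also remains open whether an amine in place of the methoxy group on the shared core would do so.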